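The compounds below may be only part of what the source reports. "The series", "measured", "known", "first", "only" and "open" are said of these compounds alone.

Measured so far in a functional assay on HT-29 cells (Homo sapiens) for inhibition, read by luminescence and CellTiter-Glo, with a stated time of 24 h; a lower number here means that less compound is needed, a higher number that more compound is needed for the effect:
Compound 1 `CCCn1nc(C(=O)N[C@H]2COc3ccccc3N(C)C2=S)nc1Cc1ccccc1`: 288 nM
Compound 2 `CN1C(=S)[C@@H](NC(=O)c2nc(Cc3ccccc3)n(CCCCC#N)n2)COc2ccccc21`: 2680 nM

Of these two compounds, compound 2 has the higher number, 2680 nM, so more of it is needed for the effect. Compound 3 `CN1C(=S)[C@@H](NC(=O)c2nc(Cc3ccccc3)n(CCCCCC#N)n2)COc2ccccc21` has not yet been measured. It differs from compound 2 by one change: cyanomethyl in place of cyano on a saturated chain carbon, four bonds along the chain from an aromatic nitrogen. In words, cyanomethyl stands in place of cyano on a saturated chain carbon, four bonds along the chain from an aromatic nitrogen.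

For the measured compounds named here, only one measured step bears on this: a 9.3-fold higher number from compound 1 to compound 2 (0.97 log units; beyond the scatter). There, cyanomethyl replaced hydrogen on a saturated chain carbon, three bonds along the chain from an aromatic nitrogen. That step brought the nitrile in, whereas compound 2 and compound 3 both carry one, so it is only a loose guide. A smaller move towards a higher number is therefore expected in this assay, and it may not exceed the scatter. The estimated step is a 1.3-fold higher number from compound 2 to compound 3 (0.12 log units; within the scatter). For compound 3 the expected value is 3500 nM, with an estimated range of 1200 nM to 10000 nM.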

Compound 3, half-maximal effective concentration: 3830 nM
Beside the measured number, compound 3's estimate is 1.1-fold (0.04 log units) below it; low and high end bracket the measured number.
By their numbers in this assay, from the lowest: compound 1; then compounds 2 and 3 (each within the scatter of the next).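

Once a nitrile is present, cyanomethyl in place of cyano on a saturated chain carbon, four bonds along the chain from an aromatic nitrogen, gives a 1.4-fold higher number from compound 2 to compound 3 (0.16 log units; within the scatter), so this assay does not separate these two nitrile-bearing chains. The large difference lies instead between compound 1 and the longer nitrile chain, with a 13-fold higher number from compound 1 to compound 3 (1.12 log units; beyond the scatter), and compound 1, at 288 nM, keeps the lowest number of the three. No measurement is available that explains these numbers.

Compound 1 differs from compound 2 and compound 3 both in having no nitrile and in having a shorter chain, so these compounds cannot show how much each feature contributes. On these data alone, it also remains open whether a plain alkyl chain of the same length, a still longer nitrile chain, or an amine or a carboxylic acid in place of the nitrile would give a number closer to that of compound 1 or to that of compound 3.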